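The source may report more compounds than this note shows. Statements on the series, on what has been measured and on what is new or still open speak of the compounds shown alone.

In an ADME assay on Huh-5-2 cells (Homo sapiens) for cytotoxicity, read by WST assay, with a stated time of 3 days (on this read-out lower numbers stand for higher toxicity in this test and higher numbers for lower toxicity in this test), compound 3 `O=c1c(OCc2ccc(Cl)cc2)c(-c2ccccc2)oc2cc(O)cc(O)c12` gives 36000 nM, the highest of the three numbers at hand. Compound 2 `COc1cccc(COc2c(-c3ccccc3)oc3cc(O)cc(O)c3c2=O)c1` gives 28000 nM, and the step of a 1.3-fold higher number from compound 2 to compound 3 (0.11 log units; within the scatter) lies within the scatter, so the two cannot be ordered. Compound 1 `O=c1c(OCc2ccccc2Br)c(-c2ccccc2)oc2cc(O)cc(O)c12` gives 12000 nM, and the steps of a 2.3-fold higher number from compound 1 to compound 2 (0.37 log units; beyond the scatter) and a 3.0-fold higher number from compound 1 to compound 3 (0.48 log units; beyond the scatter) are both beyond the scatter, though modest.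

Compound 4 `Cc1ccc(COc2c(-c3ccccc3)oc3cc(O)cc(O)c3c2=O)cc1` differs from compound 3 by methyl in place of chloro on an aromatic carbon. Among the compounds with values here, none of the measured steps changes only a single substituent on the benzyl ring in this way; each of them exchanges the whole benzyl group, and the one that replaces one para substituent pattern by another, a 1.3-fold higher number from compound 2 to compound 3 (0.11 log units; within the scatter), stays within the scatter. Within the data shown here, the three numbers lie close together, the only steps beyond the scatter being the modest 2.3-fold higher number from compound 1 to compound 2 (0.37 log units; beyond the scatter) and a 3.0-fold higher number from compound 1 to compound 3 (0.48 log units; beyond the scatter), so a step beyond the scatter in this assay is not expected here. Compound 4 is therefore expected to give about 32000 nM in this assay, between 15000 nM and 70000 nM, a step of a 1.1-fold lower number from compound 3 to compound 4 (0.05 log units; within the scatter) that is expected to stay within the scatter.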

Compound 4, half-maximal cytotoxic concentration: 40000 nM
Compound 4: middle estimate off by 1.3-fold (0.10 log units), on the low side; measured number inside the range.
By their numbers in this assay, from the lowest: compound 1; then compounds 2, 3 and 4 (each within the scatter of the next).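

In this assay, methyl in place of chloro on an aromatic carbon, para to a large group, gives a 1.1-fold higher number from compound 3 to compound 4 (0.05 log units; within the scatter), so these two single-atom substituents cannot be ordered at this position. The whole-group exchange gives a 1.4-fold higher number from compound 2 to compound 4 (0.15 log units; within the scatter), which places the 4-methylbenzyl compound with the other two in the upper cluster, while a 3.3-fold higher number from compound 1 to compound 4 (0.52 log units; beyond the scatter) is beyond the scatter but modest, leaving compound 1 alone with the lowest number. No measurement at hand accounts for these numbers.

The compounds shown leave open whether a group of another kind at this place, such as an amine or a carboxylic acid, would give a step beyond the scatter. They also do not tell whether the lower number of compound 1 goes with the bromo group itself or with where it sits on the ring.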